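From Compound 3 to Compound 4 in Paw Edema Inhibition

This account rests on a few compounds, and the source may have more. Where it says the series, first, only, none or still open, it means among the compounds named here.

In a functional assay on the whole organism (strain albino) for inhibition, with Rattus norvegicus as the target, read by paw edema, with stated times of 1 h and 2 h, at a dose of 20 mmol/kg by the intraperitoneal route (on this read-out higher numbers stand for more inhibition at the one dose given (going by the name of the read-out) and lower numbers for less inhibition), compound 1 `N#CC1=C(NCC(=O)O)N(c2ccccc2)C(=O)N2CCCCC(N3CCCC3)C12` gives 81.7%, compound 2 `N#CC1=C(NCC(=O)N2CCCC2)N(c2ccccc2)C(=O)N2CCCCC(N3CCCC3)C12` gives 49.8%, and compound 3 `N#CC1=C(/N=C/c2ccc([N+](=O)[O-])cc2)N(c2ccccc2)C(=O)N2CCCCC(N3CCCC3)C12` gives 80.9%. Compound 3 thus stands second highest of the three numbers, with compound 1 within the scatter of it and compound 2 well below, as shown by a number 31.1 percentage points higher from compound 2 to compound 3 (beyond the scatter). Compound 4 `COC(=O)C(=O)NC1=C(C#N)C2C(N3CCCC3)CCCCN2C(=O)N1c1ccccc1` differs from compound 3 by a group of 7 heavy atoms (3 carbon, 1 nitrogen, 3 oxygen; no ring) in place of a group of 11 heavy atoms (7 carbon, 2 nitrogen, 2 oxygen; one six-membered aromatic ring of carbon only), on a double-bonded ring carbon. Two measured steps at the same ring carbon bear on this change: a number 0.8 percentage points lower from compound 1 to compound 3 (within the scatter), and a number 31.9 percentage points lower from compound 1 to compound 2 (beyond the scatter). Replacements at this position have thus ranged from no change to a large loss, so the expected step of a number 15.9 percentage points lower from compound 3 to compound 4 (beyond the scatter) is set modestly downward with wide uncertainty. Compound 4 is therefore estimated at 65%, within a range from 40% to 88%.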

Compound 4, a percentage reported as inhibition, in the whole organism at one dose (the size of the read-out at that dose, not a potency): 85.6%
The estimate for compound 4 lay 20.6 percentage points below the measured number; measured number inside the range.
By their numbers in this assay, from the lowest: compound 2; then compounds 3, 1 and 4 (each within the scatter of the next).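

Replacing the group at this ring carbon with ((methoxycarbonyl)carbonyl)amino leaves the read-out level, with a number 4.7 percentage points higher from compound 3 to compound 4 (within the scatter), so a group with no ring serves here as well as one bearing the six-membered aromatic ring. On the amine nitrogen, the same group stands level with carboxymethyl, with a number 3.9 percentage points higher from compound 1 to compound 4 (within the scatter), while against ((pyrrolidin-1-yl)carbonyl)methyl there is a number 35.8 percentage points higher from compound 2 to compound 4 (beyond the scatter), which sets compound 2 apart from the other three. Nothing measured here gives a reason for this.

The compounds shown leave open whether a free carboxylic acid in place of the methyl ester of compound 4, or a longer chain on the amine nitrogen, would stay level with it.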